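A few compounds are considered here, and "the series" means these few. Any claim that something is new, unique, unknown or untested is made for them only; others in the source may bear on it.

In a physicochemical assay for solubility, in phosphate buffer, measured as kinetic solubility, at pH 7.4 (a higher number here means a more soluble compound, a lower number a less soluble compound), compound 1 `Cc1oc(-c2c(Cl)cccc2C(F)(F)F)nc1CN1CCC(C(=O)NCCCN2C[C@H](C)C[C@H](C)C2)CC1` gives 65.1 ug/mL. Compound 2 `Cc1ccc(-c2nc(CN3CCC(C(=O)NCCCN4C[C@H](C)C[C@H](C)C4)CC3)c(C)o2)cc1` gives > 69 ug/mL. That reading is a limit of the assay and not a number, so compound 2 has no exact position on the scale.

Among the measured compounds shown here, the only measured step that bears on what follows is an at least 1.0-fold higher number from compound 1 to compound 2 (0.02 log units; that floor lies within the scatter), with 4-methylphenyl in place of 2-chloro-6-(trifluoromethyl)phenyl on an aromatic carbon.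

Compound 3 `CCc1ccccc1-c1nc(CN2CCC(C(=O)NCCCN3C[C@H](C)C[C@H](C)C3)CC2)c(C)o1` keeps the shared core and changes that same group: 2-ethylphenyl in place of 4-methylphenyl on an aromatic carbon. Here 2-ethylphenyl stands in place of 4-methylphenyl.

Going by an at least 1.0-fold higher number from compound 1 to compound 2 (0.02 log units; that floor lies within the scatter), no step beyond the scatter is expected in this assay for this change, and no direction can be called. The step estimated is an at least 1.0-fold lower number from compound 2 to compound 3 (0.02 log units; that floor lies within the scatter). For compound 3 the expected value is 65 ug/mL, with an estimated range from 35 ug/mL to 80 ug/mL.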

Compound 3, solubility: 55.9 ug/mL
Beside the measured number, compound 3's estimate is 1.2-fold (0.07 log units) above it, within the range that was stated.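

In this assay, 2-ethylphenyl in place of 2-chloro-6-(trifluoromethyl)phenyl gives a 1.2-fold lower number from compound 1 to compound 3 (0.07 log units; within the scatter), so a group of carbon only and a group carrying chlorine and fluorine read alike at this position, a comparison that rests on two real numbers. Set against 4-methylphenyl, 2-ethylphenyl gives an at least 1.2-fold lower number from compound 2 to compound 3 (0.09 log units; that floor lies within the scatter), and this is only a floor, so the true size of that step remains unknown. Compound 2 gives a limit of the assay and not a number: the limit of > 69 ug/mL in this assay, at which 1 of the 3 values shown sits.

As far as these compounds go, how far compound 2 really lies from compound 3, and whether that gap goes beyond the scatter, stays open. Also open, from the compounds shown here alone, is how the reading would move with a more different group on the phenyl ring, such as an amine or a carboxylic acid.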